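This account rests on a few compounds, and the source may have more. Where it says the series, first, only, none or still open, it means among the compounds named here.

Working notes on the series. In a functional assay on the whole organism for inhibition, with Mythimna separata as the target, with a stated time of 5 days (a lower number here means that less compound is needed, a higher number that more compound is needed for the effect), compound 1 `CC(C)(C)n1ncc(OCc2nnc(-c3ccc(Br)cc3)o2)c(Cl)c1=O` gives 21400 nM. Of the two numbers measured in this assay, this is the lower one. Compound 2 `CC(C)(C)n1ncc(OCc2nnc(-c3ccc(Cl)cc3Cl)s2)c(Cl)c1=O` gives 62200 nM in this assay, and the gap from compound 1 to compound 2 lies beyond the usual scatter. Compound 3 `CCn1ncc(OCc2nnc(-c3ccccc3)o2)c(Cl)c1=O` gives > 299000 nM in this assay, which is a limit of the assay and not a number, namely (the limit of > 299000 nM in this assay, at which 1 of the 3 values shown sits).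

Compound 4 `Cc1cc(C)cc(-c2nnc(COc3cnn(C(C)(C)C)c(=O)c3Cl)o2)c1` is not yet measured in this assay. It differs from compound 1 in one place: 3,5-dimethylphenyl in place of 4-bromophenyl on an aromatic carbon. Going by the values given here, no measured pair isolates this change, so no measured step gives its size. The step is estimated to be small, a 1.4-fold higher number from compound 1 to compound 4 (0.15 log units; within the scatter), with no clear direction beyond the scatter. Compound 4 is therefore expected to give 30000 nM in this assay, with an estimated range from 8000 nM to 120000 nM.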

Compound 4, half-maximal effective concentration: > 299000 nM
Compound 4: a limit, no number; the forecaster's own chance of this, stated with the estimate: 20%; at least 9.9-fold (0.99 log units) between middle value and limit.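

Going by these compounds alone, this is the first measured step that isolates the aromatic group on the five-membered ring: with the rest of the structure held as in compound 1, 3,5-dimethylphenyl in place of 4-bromophenyl gives an at least 13-fold higher number from compound 1 to compound 4 (1.14 log units; beyond the scatter). In this assay this position therefore does not tolerate every aromatic group, although both groups count as one six-membered aromatic ring of carbon only, with no hydrogen-bond donors or acceptors. The value of compound 4 is a limit of the assay and not a number: the limit of > 299000 nM in this assay, at which 2 of the 4 values shown sit.

The compounds shown do not separate the loss of the bromine from the gain of the two methyl groups, and so leave open which of these matters. Also open, going by these compounds, is how a 4-methylphenyl, 4-methoxyphenyl or 4-trifluoromethylphenyl group would read at this position.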